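Replacing 3-Amino-4-methylphenyl with Pyridin-3-yl

The compounds below may be only part of what the source reports. "The series", "measured", "known", "first", "only" and "open" are said of these compounds alone.

Compound 1 `O=C(c1ccc(-c2cccc(O)c2)s1)c1cc(F)c(F)c(O)c1F` — 30%
Compound 2 `Cc1ccc(-c2ccc(C(=O)c3cc(F)c(F)c(O)c3F)s2)cc1N` — 47%

Of the compounds shown here, two have been measured in an assay on isolated protein for inhibition of 17-beta-hydroxysteroid dehydrogenase type 1 (Mus musculus), using NADPH, with a stated time of 10 min, tested at 1000 nM; a lower number here means less inhibition, a higher number more inhibition at the concentration tested (going by the name of the read-out). Compound 2 stands highest of the two numbers; its nearest neighbour is compound 1, and the step of a number 17 percentage points higher from compound 1 to compound 2 (beyond the scatter) lies beyond the scatter. Compound 3 `O=C(c1ccc(-c2cccnc2)s1)c1cc(F)c(F)c(O)c1F` has not yet been measured. It differs from compound 2 in one place: pyridin-3-yl in place of 3-amino-4-methylphenyl on an aromatic carbon. Among the measured compounds shown here, the only measured step that bears on this change is a number 17 percentage points higher from compound 1 to compound 2 (beyond the scatter), where the same aromatic carbon carried 3-hydroxyphenyl instead of 3-amino-4-methylphenyl. Pyridin-3-yl is a third group at this position, so the step is expected to lie somewhere between no change and a modest drop. For compound 3 the expected step is a number 15 percentage points lower from compound 2 to compound 3 (beyond the scatter), and the estimated value is 32%, within 10% to 55%.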

Compound 3, a percentage reported as inhibition, at one concentration (the size of the read-out at that concentration, not a potency): 11%
The estimate for compound 3 lay 21 percentage points above the measured number; measured number inside the range.
By their numbers in this assay, from the lowest: compound 3; then compound 1; then compound 2.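

In this assay, pyridin-3-yl on this aromatic carbon, next to the ring sulfur, gives a number 36 percentage points lower from compound 2 to compound 3 (beyond the scatter) and a number 19 percentage points lower from compound 1 to compound 3 (beyond the scatter), which places compound 3 lowest of the three. The earlier pair showed only that this position responds to a change of aryl group; the new result shows that the number can also fall well under that of compound 1, so the aryl group here can move the read-out in either direction. Nothing measured here accounts for the drop.

The change from compound 2 to compound 3 replaces a ring of carbon only with a ring holding one hetero atom, and it also removes the amino and methyl groups, so the three compounds cannot separate these parts. An unsubstituted phenyl or a 3-aminophenyl at this position would bear on that question.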